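Cyclopentyl to 2-Ethylphenyl on an Amide-Type Nitrogen

The source may report more compounds than this note shows. Statements on the series, on what has been measured and on what is new or still open speak of the compounds shown alone.

Compound 1, `O=C(Nc1cccc(CNc2nccnc2Cl)c1)Nc1ccccc1Cl`, gives 7130 nM in a functional assay on MGC-803 cells (Homo sapiens) for antiproliferative activity, read by MTT assay, with a stated time of 48 h; on this read-out higher numbers stand for weaker inhibition and lower numbers for stronger inhibition.
Compound 2, `O=C(Nc1cccc(CNc2nccnc2Cl)c1)Nc1ccc(Cl)cc1Br`, gives 7480 nM in this assay.
Compound 3, `O=C(Nc1cccc(CNc2nccnc2Cl)c1)NC1CCCC1`, gives 23400 nM in this assay.

Among these three, compound 3 has the highest number, that is, the weakest inhibition; its steps to the other two are both beyond the scatter, while compounds 1 and 2 sit within the scatter of each other, as a 1.0-fold higher number from compound 1 to compound 2 (0.02 log units; within the scatter) shows. Compound 3 is the only one that carries a non-aromatic ring on the amide-type nitrogen, the other two carry an aromatic ring there.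

Compound 4, `CCc1ccccc1NC(=O)Nc1cccc(CNc2nccnc2Cl)c1`, has not been measured. It differs from compound 3 in one place: 2-ethylphenyl in place of cyclopentyl on an amide-type nitrogen.

Within the data shown here, two measured steps bear on this change, both running in the opposite direction, from an aromatic ring to cyclopentyl: a 3.3-fold higher number from compound 1 to compound 3 (0.52 log units; beyond the scatter) and a 3.1-fold higher number from compound 2 to compound 3 (0.50 log units; beyond the scatter). Going back from cyclopentyl to an aromatic ring should therefore lower the number by a modest step of about that size in this assay. Compound 4 is thus expected to land near compounds 1 and 2, an estimated 2.9-fold lower number from compound 3 to compound 4 (0.47 log units; beyond the scatter), giving an expected value of 8000 nM with a range from 3500 nM to 18000 nM.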

Compound 4, half-maximal inhibitory concentration: 9370 nM
Compound 4: middle estimate off by 1.2-fold (0.07 log units), on the low side; the measured number falls inside the stated range.
By their numbers in this assay, from the lowest: compounds 1, 2 and 4 (each within the scatter of the next); then compound 3.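

In this assay the change from a non-aromatic ring to an aromatic one can now be read directly, without reversing an earlier step: 2-ethylphenyl in place of cyclopentyl gives a modest gain in inhibition (a 2.5-fold lower number from compound 3 to compound 4 (0.40 log units; beyond the scatter)). This aromatic ring carries only carbon, yet compound 4 stays within the scatter of both halogen-bearing compounds, for ethyl in place of chloro (a 1.3-fold higher number from compound 1 to compound 4 (0.12 log units; within the scatter)) and for 2-ethylphenyl in place of 2-bromo-4-chlorophenyl (a 1.3-fold higher number from compound 2 to compound 4 (0.10 log units; within the scatter)), so among these three compounds a halogen on the ring is not needed to reach this level. The data offer no measured explanation for the difference between the aromatic rings and cyclopentyl.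

As far as these compounds go, it remains open whether a plain phenyl ring, with no group on it, would match these three compounds, or whether a methoxy group, an amine or a carboxylic acid on the ring would move the number. It is also unknown how an open chain such as butyl on the same nitrogen would compare with cyclopentyl and the aromatic rings.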